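This account rests on a few compounds, and the source may have more. Where it says the series, first, only, none or still open, it means among the compounds named here.

Measured so far in a functional assay on NCI-H460 cells (Homo sapiens) for antiproliferative activity, read by MTT assay, with a stated time of 48 h; on this read-out lower numbers stand for stronger inhibition and higher numbers for weaker inhibition:

Compound 1 `COc1ccccc1C(=O)Nc1nnc(SCC(=O)Nc2ccc(C)cn2)s1` — in this assay compound 1 reaches only the limit > 80000 nM.
Compound 2 `COc1ccccc1C(=O)Nc1nnc(SCC(=O)Nc2ccc(Cl)cn2)s1` — in this assay compound 2 reaches only the limit > 80000 nM.
Compound 3 `O=C(CSc1nnc(NC(=O)CCl)s1)Nc1ccc(Cl)cn1` — in this assay compound 3 gives 5700 nM.

Compound 3 thus holds the only number shown in this series; the other two values are limits, (the limit of > 80000 nM in this assay, at which 2 of the 3 values shown sit). The step of an at least 14-fold lower number from compound 2 to compound 3 (1.14 log units; beyond the scatter) goes with chloromethyl in place of 2-methoxyphenyl on a carbonyl carbon and is the only readable movement so far.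

Compound 4 `Cc1ccc(NC(=O)CSc2nnc(NC(=O)CCl)s2)nc1` differs from compound 3 by methyl in place of chloro on an aromatic carbon. For the measured compounds named here, the one measured step that touches this position, a step that the two limits leave unreadable from compound 1 to compound 2, cannot be sized because the limit of > 80000 nM in this assay, at which 2 of the 3 values shown sit, applies to both of its ends. There is therefore no evidence in this assay that exchanging methyl and chloro on this ring moves the number beyond the scatter, in either direction. The step expected from compound 3 to compound 4 is accordingly a 1.4-fold higher number from compound 3 to compound 4 (0.15 log units; within the scatter), essentially none. Compound 4 is estimated at 8000 nM in this assay, with a range from 2500 nM to 30000 nM.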

Compound 4, half-maximal inhibitory concentration: 15400 nM
Estimate against measurement, compound 4: 1.9-fold (0.28 log units) below; low and high end bracket the measured number.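

In this assay the change from 5-chloropyridin-2-yl to 5-methylpyridin-2-yl now has a readable size, with chloro giving the lower number on this core: a 2.7-fold higher number from compound 3 to compound 4 (0.43 log units; beyond the scatter). The same exchange on the core carrying 2-methoxyphenyl cannot be read, since both of its ends are limits: the limit of > 80000 nM in this assay, at which 2 of the 4 values shown sit. Chloromethyl in place of 2-methoxyphenyl now also has a methyl-bearing pair, an at least 5.1-fold lower number from compound 1 to compound 4 (0.71 log units; beyond the scatter), so the number falls on going to chloromethyl in both pairs shown: the same change on two cores in this assay, an at least 14-fold lower number (1.14 log units; beyond the scatter) from compound 2 to compound 3 and an at least 5.1-fold lower number (0.71 log units; beyond the scatter) from compound 1 to compound 4; the limit leaves it open whether they differ.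

Going by these compounds, whether the gap between chloro and methyl holds on other cores remains open, as does the outcome with an amine or a carboxylic acid at this ring position. Also open, on these data alone, is how a longer chain or an aminomethyl group on the carbonyl carbon compares with chloromethyl.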